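Swapping a methyl for an isoxazole ring: permeability outlook

The source may report more compounds than this note shows. Statements on the series, on what has been measured and on what is new or still open speak of the compounds shown alone.

Measured so far in an ADME assay on MDCK-II cells (Canis lupus familiaris) for permeability; on this read-out lower numbers stand for lower permeability and higher numbers for higher permeability:
compound 1 `Cc1ccc(NS(=O)(=O)c2cc(C(=O)NCc3nc(C)no3)ccc2C)cc1`: 20 10^-6 cm/s
compound 2 `COc1ccc(C(=O)NC(C)c2cnn(C)n2)cc1S(=O)(=O)Nc1ccc(Cl)cc1`: 16 10^-6 cm/s; 11 10^-6 cm/s (2 entries)

Compound 1 stands with the only single number shown in this assay, where compound 1 gives 20 10^-6 cm/s. Compound 2 has several entries, (the several entries of compound 2 in this assay, 16 10^-6 cm/s; 11 10^-6 cm/s (2 entries)), which show how much repeat measurements can wander.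

Compound 3 `Cc1noc(CNC(=O)c2ccc(C)c(S(=O)(=O)Nc3ccc(-c4ccno4)cc3)c2)n1` differs from compound 1 in one place: 1,2-oxazol-5-yl in place of methyl on an aromatic carbon. Going by the values given here, no measured pair shows this change, so the expectation rests on compound 1 alone. The added ring is expected to lower permeability only modestly, roughly within the usual scatter. Compound 3 is therefore expected to give about 12 10^-6 cm/s, with a range from 5 10^-6 cm/s to 25 10^-6 cm/s. The estimated step of a 1.7-fold lower number from compound 1 to compound 3 (0.22 log units; within the scatter) is small and downward.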

Compound 3, apparent permeability in the MDCK-II assay: 6 10^-6 cm/s
The estimate for compound 3 lay 2.0-fold (0.30 log units) above the measured number; the measured number falls inside the stated range.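

At this aromatic carbon, para to a large group, the change from methyl to 1,2-oxazol-5-yl can now be read as a step: in the MDCK-II assay it gives a 3.3-fold lower number from compound 1 to compound 3 (0.52 log units; beyond the scatter) and so moves the number by more than repeat measurements usually do. In a physicochemical assay for lipophilicity, using the shake flask method, in phosphate buffer, measured as octanol-water partition, at pH 7.4 (on this read-out lower numbers stand for lower lipophilicity and higher numbers for higher lipophilicity), compound 1 gives 2.7 and compound 3 gives 2.3. Lipophilicity moves down with it, which may partly account for the lower permeability, although a single pair cannot settle this: the measured distribution coefficient of compound 1, 2.7, and of compound 3, 2.3, a number 0.40 log units lower (beyond the scatter).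

As far as these compounds go, whether the same swap acts alike on another core stays open. So does what an amine or a carboxylic acid on that carbon would give.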